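This account rests on a few compounds, and the source may have more. Where it says the series, first, only, none or still open, it means among the compounds named here.

Measured compounds:
compound 1 `CCCCCCCCCCCCC(C)(C)C(=O)Nc1c(C)cc(C)c2c1OC(C)(C)C2`, 33 nM
compound 2 `Cc1cc(C)c(NC(=O)C(C)(C)CCCCCc2ccccc2)c2c1CC(C)(C)O2`, 120 nM
compound 3 `Cc1cc(C)c(NC(=O)C(C)(C)CCCc2ccc(CC(C)C)cc2)c2c1CC(C)(C)O2`, 40 nM

In an assay for inhibition of acyl-CoA:cholesterol acyltransferase (Oryctolagus cuniculus), using microsomes (a lower number here means a stronger inhibitor, a higher number a weaker inhibitor), compound 3 gives the second highest of the three numbers; its nearest neighbour is compound 1, a step that lies within the scatter, and its furthest is compound 2, beyond the scatter. Compound 4 `Cc1ccc(OCCCCCCC(C)(C)C(=O)Nc2c(C)cc(C)c3c2OC(C)(C)C3)cc1` differs from compound 3 in one place: 3-(4-methylphenoxy)propyl in place of 4-isobutylphenyl on a saturated chain carbon, four bonds along the chain from a carbonyl carbon. Going by the values given here, two measured steps bear on this: a 1.2-fold higher number from compound 1 to compound 3 (0.08 log units; within the scatter) and a 3.0-fold lower number from compound 2 to compound 3 (0.48 log units; beyond the scatter). An aromatic ring placed further out on the chain, as in compound 2, went with a modestly higher number, so for compound 4 a modest rise in this assay is expected, a 1.8-fold higher number from compound 3 to compound 4 (0.24 log units; within the scatter). Compound 4 is estimated at 70 nM, between 30 nM and 170 nM.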

Compound 4, half-maximal inhibitory concentration: 50 nM
Beside the measured number, compound 4's estimate is 1.4-fold (0.15 log units) above it; measured number inside the range.
By their numbers in this assay, from the lowest: compounds 1, 3 and 4 (each within the scatter of the next); then compound 2.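

In this assay, 3-(4-methylphenoxy)propyl, which brings an oxygen into the chain, does about as well as 4-isobutylphenyl (a 1.3-fold higher number from compound 3 to compound 4 (0.10 log units; within the scatter)), and the 4-methylphenoxy chain also stays close to the purely saturated chain (a 1.5-fold higher number from compound 1 to compound 4 (0.18 log units; within the scatter)). The step from the phenyl-ended chain lies beyond the scatter (a 2.4-fold lower number from compound 2 to compound 4 (0.38 log units; beyond the scatter)), so an aromatic ring on a long chain does not by itself go with the higher number of compound 2. Nothing measured here explains these steps. On these data alone, whether an amine or a carboxylic acid in place of 4-methylphenoxy would hold this level remains open, as does the effect of a longer chain.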